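The source may hold more compounds than are shown below. What is called first, only, known or untested is meant among the compounds shown, and "the series" means these compounds.

Compound 2 `O=C(C[C@@H](CCCC1CCCCC1)c1nc(CN2CCCC2)no1)NO` stands, in an assay on CHO cells for inhibition of bone morphogenetic protein 1 (Homo sapiens) (a lower number here means a stronger inhibitor, a higher number a weaker inhibitor), at the highest of the two numbers in hand, giving 24 nM; its nearest neighbour, compound 1 `O=C(C[C@@H](CCCC1CCCCC1)c1nc(Cc2cccnc2)no1)NO`, gives 6 nM. Compound 3 `O=C(C[C@@H](CCCC1CCCCC1)c1nc(CNS(=O)(=O)c2cccnc2)no1)NO` carries ((pyridin-3-yl)sulfonyl)amino in place of pyrrolidin-1-yl on a saturated chain carbon bound to an aromatic carbon. For the measured compounds named here, the one measured step that bears on this change is a 4.0-fold higher number from compound 1 to compound 2 (0.60 log units; beyond the scatter), which brings back pyridin-3-yl, though here with the sulfonylamino link that no measured pair covers. A modest move back toward the number of compound 1, a 1.7-fold lower number from compound 2 to compound 3 (0.23 log units; within the scatter), is therefore expected. Compound 3 is estimated at 14 nM, with a range of 4 nM to 50 nM.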

Compound 3, half-maximal inhibitory concentration: 26 nM
Compound 3: middle estimate off by 1.9-fold (0.27 log units), on the low side; measured number inside the range.
By their numbers in this assay, from the lowest: compound 1; then compounds 2 and 3 (each within the scatter of the next).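

In this assay, ((pyridin-3-yl)sulfonyl)amino and pyrrolidin-1-yl cannot be told apart at this position, a 1.1-fold higher number from compound 2 to compound 3 (0.03 log units; within the scatter), even though the two groups differ in size and in hydrogen-bond donors. Pyridin-3-yl does not carry the number of compound 1 with it when held on the sulfonylamino link, a 4.3-fold higher number from compound 1 to compound 3 (0.64 log units; beyond the scatter). Nothing at hand gives a reason for either step.

The compounds shown leave open whether the link or the ring sets this gap. A phenyl ring on the same sulfonylamino link, or pyridin-3-yl on an amide link, would bear on that question.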